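Exchanging methoxy for dimethylamino in a growth-inhibition series

The source may hold more compounds than are shown below. What is called first, only, known or untested is meant among the compounds shown, and "the series" means these compounds.

In a functional assay on KB cells (Homo sapiens) for antiproliferative activity, read by sulforhodamine B assay, with a stated time of 3 days (a lower number here means a stronger inhibitor of growth, a higher number a weaker inhibitor of growth), compound 3 `COCC(=O)Nc1cccc(Nc2ncc(F)c(Nc3ccc(F)cc3)n2)c1` gives 6250 nM as the lower of the two numbers that are not limits. Compound 1 `O=C(Nc1ccccn1)c1cccc(Nc2ncc(F)c(Nc3ccc(F)cc3)n2)c1` gives 20000 nM by comparison. Compound 2 `O=C(Nc1nccs1)c1cccc(Nc2ncc(F)c(Nc3ccc(F)cc3)n2)c1` stands at > 10000 nM which is only a limit. Compound 4 `CN(C)CC(=O)Nc1cccc(Nc2ncc(F)c(Nc3ccc(F)cc3)n2)c1` differs from compound 3 through dimethylamino in place of methoxy on a saturated chain carbon bound to a carbonyl carbon with dimethylamino in place of methoxy on a saturated chain carbon bound to a carbonyl carbon. Among the compounds with values here, no measured step touches this place. The clearest one, exchanging a whole (pyridin-2-yl)carbamoyl group, is a 3.2-fold lower number from compound 1 to compound 3 (0.51 log units; beyond the scatter) and stays modest, so a smaller exchange is expected to stay within the scatter. The expected result in this assay is a 1.3-fold lower number from compound 3 to compound 4 (0.10 log units; within the scatter) and no step beyond the scatter. Compound 4 is estimated at 5000 nM with 1500 nM to 15000 nM as the expected range.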

Compound 4, concentration for 50% growth inhibition: 1260 nM
The estimate for compound 4 lay 4.0-fold (0.60 log units) above the measured number; measured number below the stated range.
By their numbers in this assay, from the lowest: compound 4; then compound 3; then compound 1.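

In this assay, within the data shown here, the saturated chain carbon bound to a carbonyl carbon turns out to respond to exchange: dimethylamino in place of methoxy gives a 5.0-fold lower number from compound 3 to compound 4 (0.70 log units; beyond the scatter) at a place no earlier step had touched. The whole groups exchanged on the aromatic carbon now give a 16-fold lower number from compound 1 to compound 4 (1.20 log units; beyond the scatter) and an at least 7.9-fold lower number from compound 2 to compound 4 (0.89 log units; beyond the scatter) in the same assay. The second of these is only a floor, as compound 2 stands at a limit: the limit of > 10000 nM in this assay, at which 1 of the 4 values shown sits.

The compounds shown leave open whether another amine, such as pyrrolidine, or a longer chain would hold this gain at the same place. As far as these compounds go, a carboxylic acid there also remains untested among them.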